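Bromobenzyl thioether: an expectation from two chain analogues

The compounds below may be only part of what the source reports. "The series", "measured", "known", "first", "only" and "open" are said of these compounds alone.

Compound 1 `CCOC(=O)CCSc1nc2ccccc2n1CC(=O)O` gives 11400 nM
Compound 2 `CCOC(=O)CCCCCSc1nc2ccccc2n1CC(=O)O` gives 1010 nM

Among the compounds with values here, in an assay on HEK293 cells for displacement of a labelled ligand from prostaglandin D2 receptor 2 (Homo sapiens) (a lower number here means a stronger inhibitor, a higher number a weaker inhibitor), compound 1 stands at the higher of the two numbers, with compound 2 as its only neighbour, reached by an 11-fold lower number from compound 1 to compound 2 (1.05 log units; beyond the scatter). Compound 3 `O=C(O)Cn1c(SCc2ccc(Br)cc2)nc2ccccc21` differs from compound 1 by 4-bromophenyl in place of (ethoxycarbonyl)methyl on a saturated chain carbon bound to a sulfur. Within the data shown here, no measured step covers this exchange; the one step known shows that altering the chain bound to the sulfur moved the number by a large margin. A shift of comparable scale toward a lower number is therefore expected for compound 3, a 14-fold lower number from compound 1 to compound 3 (1.15 log units; beyond the scatter). Compound 3 is estimated at 800 nM, within 100 nM to 6000 nM.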

Compound 3, half-maximal inhibitory concentration: 220 nM
For compound 3 the middle estimate is 3.6-fold (0.56 log units) above the measured one; the measured number falls inside the stated range.
By their numbers in this assay, from the lowest: compound 3; then compound 2; then compound 1.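

In this assay, the exchange of (ethoxycarbonyl)methyl for 4-bromophenyl on a saturated chain carbon bound to a sulfur gives a 52-fold lower number from compound 1 to compound 3 (1.71 log units; beyond the scatter). The earlier compounds shown here varied only a chain ending in an ethyl ester, whereas this step shows that the position also tolerates an aromatic ring carrying bromine, with no ester present. Nothing at hand explains this shift. The compounds shown leave open how much of the step belongs to the ring and how much to the bromine. Plain phenyl or 4-chlorophenyl on the same carbon would separate the two.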